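Notes on a dihydroxyphenyl variant of compound 1

The source may hold more compounds than are shown below. What is called first, only, known or untested is meant among the compounds shown, and "the series" means these compounds.

Measured so far:
Compound 1 `O=C(O)/C=C/c1cn(-c2ccc(O)cc2)nc1-c1ccc(O)cc1` in a functional assay (Mus musculus) for inhibition, with a stated time of 5 days (on this read-out higher numbers stand for weaker inhibition and lower numbers for stronger inhibition), gives > 100000 nM, a limit of the assay.
Compound 2 `O=Cc1cn(-c2ccc(O)cc2)nc1-c1ccccc1` gives > 100000 nM, also a limit.
Compound 3 `CCOC(=O)/C=C/c1cn(-c2ccc(O)cc2)nc1-c1cccc(O)c1` gives 14000 nM.

Compound 1 stands at the limit of > 100000 nM in this assay, at which 2 of the 3 values shown sit; it gives no number, only a limit, and compound 2 sits at the same limit. Among the measured compounds shown here, the one numeric value in the set belongs to compound 3. For the measured compounds named here, no pair of measured compounds differs in a single place, so no step can be read from the numbers.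

Compound 4 `O=C(O)/C=C/c1cn(-c2ccc(O)cc2)nc1-c1cc(O)ccc1O` differs from compound 1 by 2,5-dihydroxyphenyl in place of 4-hydroxyphenyl on an aromatic carbon.

With compound 1 at a limit, only the direction of the step is open to expectation. Compound 4 is expected to reach a number, with the step of an at least 1.6-fold lower number from compound 1 to compound 4 (0.22 log units; that floor lies within the scatter); compound 4 is estimated at 60000 nM, between 15000 nM and 300000 nM.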

Compound 4, half-maximal inhibitory concentration: > 100000 nM
Compound 4: a limit, no number; the forecaster's own chance of this, stated with the estimate: 55%; at least 1.6-fold (0.22 log units) between middle value and limit.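

Compound 1 and compound 4 both sit at a limit, so no step can be read between them: the limit of > 100000 nM in this assay, at which 3 of the 4 values shown sit.

The compounds shown leave open whether 2,5-dihydroxyphenyl in place of 4-hydroxyphenyl shifts the read-out at all.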